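A few compounds are considered here, and "the series" means these few. Any claim that something is new, unique, unknown or untested is made for them only; others in the source may bear on it.

Measured compounds:
compound 1 `O=C(O[C@H]1C[C@H](n2cc(F)c(=O)[nH]c2=O)O[C@@H]1COP(=O)(O)Oc1cccnc1)c1ccccc1` — 6900 nM
compound 2 `O=C(O[C@H]1C[C@H](n2cc(F)c(=O)[nH]c2=O)O[C@@H]1COP(=O)(O)Oc1ccc2ncccc2c1)c1ccccc1` — 7300 nM

In a functional assay on HeLa cells (Homo sapiens) for cytotoxicity, read by MTT assay, with a stated time of 48 h (a lower number here means a stronger inhibitor, a higher number a weaker inhibitor), compound 1 gives 6900 nM. It stands with the smaller of the two numbers shown, yet the gap is no real separation, since a 1.1-fold higher number from compound 1 to compound 2 (0.02 log units; within the scatter). Compound 2 gives 7300 nM in this assay.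

Compound 3 `C[N+]1(C)CCC(OP(=O)([O-])OC[C@H]2O[C@@H](n3cc(F)c(=O)[nH]c3=O)C[C@@H]2OC(=O)c2ccccc2)CC1` differs from compound 1 by a group of 12 heavy atoms (7 carbon, 1 nitrogen, 3 oxygen, 1 phosphorus; one six-membered non-aromatic ring with 1 hetero atom) in place of a group of 10 heavy atoms (5 carbon, 1 nitrogen, 3 oxygen, 1 phosphorus; one six-membered aromatic ring with 1 hetero atom), on an oxygen on a saturated carbon. Going by the values given here, the only measured step at this oxygen, quinolin-6-yl in place of pyridin-3-yl, was a 1.1-fold higher number from compound 1 to compound 2 (0.02 log units; within the scatter), which shows that swapping one aromatic group for another there leaves this assay unmoved. Among the compounds with values here, the change to compound 3 goes further, bringing in a non-aromatic ring with no hydrogen-bond donor, and no measured pair covers such a change. Within the data shown here, with only that one flat step as a guide, compound 3 is expected to show a 1.2-fold higher number from compound 1 to compound 3 (0.06 log units; within the scatter), with no step beyond the scatter as the likeliest outcome. The estimate for compound 3 is therefore 8000 nM, within a range from 3000 nM to 25000 nM.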

Compound 3, half-maximal inhibitory concentration: 27200 nM
Compound 3: middle estimate off by 3.4-fold (0.53 log units), on the low side, outside the stated range (above it).
By their numbers in this assay, from the lowest: compounds 1 and 2 (each within the scatter of the next); then compound 3.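

This oxygen is not indifferent to every change: the swap between aromatic groups left this assay flat, but the group with a six-membered non-aromatic ring gives a 3.9-fold higher number from compound 1 to compound 3 (0.60 log units; beyond the scatter). So the tolerance seen between compound 1 and compound 2 does not extend to this replacement, in which the aromatic ring is lost, the hydrogen-bond donor count of the group changes and the group gains heavy atoms, all in a single step that cannot separate these differences. Nothing available accounts for the step.

The compounds shown leave open whether a plain cyclohexyl group at this oxygen would stand with compound 1 or with compound 3. They also leave open whether a piperidine ring with a free amine would give the same number as compound 3.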